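Exchanging the aryl group on the amine nitrogen

The compounds below may be only part of what the source reports. "The series", "measured", "known", "first", "only" and "open" are said of these compounds alone.

compound 1 `CC(C)c1ccc(-c2nc(SCc3cn(CC(=O)NC(=O)Nc4ccccn4)nn3)nc(Nc3cccc([N+](=O)[O-])c3)c2C#N)cc1` — > 64000 nM
compound 2 `CC(C)c1ccc(-c2nc(SCc3cn(CC(=O)NC(=O)Nc4ccccn4)nn3)nc(Nc3ccccc3F)c2C#N)cc1` — > 64000 nM
compound 3 `Cc1cccc(Nc2nc(SCc3cn(CC(=O)NC(=O)Nc4ccccn4)nn3)nc(-c3ccc(C(C)C)cc3)c2C#N)c1` — 25300 nM

In a functional assay on MGC-803 cells (Homo sapiens) for inhibition, read by MTT assay, with a stated time of 72 h (a higher number here means a weaker inhibitor, a lower number a stronger inhibitor), compound 3 is the only one of the three with a true number, 25300 nM. For compound 1 the value > 64000 nM is a limit of the assay, not a number. For compound 2 the value > 64000 nM is likewise a limit. Compound 4 `CC(C)c1ccc(Nc2nc(SCc3cn(CC(=O)NC(=O)Nc4ccccn4)nn3)nc(-c3ccc(C(C)C)cc3)c2C#N)cc1` differs from compound 3 by 4-isopropylphenyl in place of 3-methylphenyl on a nitrogen on an aromatic ring. For the measured compounds named here, no measured step alters the group on that nitrogen in this way: an at least 2.5-fold lower number from compound 1 to compound 3 (0.40 log units; beyond the scatter) and an at least 2.5-fold lower number from compound 2 to compound 3 (0.40 log units; beyond the scatter) both end at compound 3 and are read against the limit (the limit of > 64000 nM in this assay, at which 2 of the 3 values shown sit), while a step that the two limits leave unreadable from compound 1 to compound 2. These show the position matters, but not how a 4-isopropylphenyl fares. The expected step is a 1.2-fold higher number from compound 3 to compound 4 (0.07 log units; within the scatter). For compound 4 the estimate is 30000 nM, with a range from 8000 nM to 100000 nM.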

Compound 4, half-maximal inhibitory concentration: 15800 nM
Estimate against measurement, compound 4: 1.9-fold (0.28 log units) above; the measured number falls inside the stated range.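

In this assay, 4-isopropylphenyl in place of 3-methylphenyl on the nitrogen gives a 1.6-fold lower number from compound 3 to compound 4 (0.20 log units; within the scatter), so the two groups cannot be told apart here. Against the other two aryl groups, the same 4-isopropylphenyl gives an at least 4.0-fold lower number from compound 2 to compound 4 (0.60 log units; beyond the scatter) and an at least 4.0-fold lower number from compound 1 to compound 4 (0.60 log units; beyond the scatter); both steps are read against a limit, not a number: the limit of > 64000 nM in this assay, at which 2 of the 4 values shown sit. Of the four compounds, only those with 3-methylphenyl and 4-isopropylphenyl give true numbers.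

The compounds shown leave open whether the alkyl group itself or its place on the ring matters, since 3-isopropylphenyl and 4-methylphenyl do not appear among them. As far as these compounds go, how an amine or a carboxylic acid on this aryl ring would fare also remains open.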